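Cytotoxicity series: thiophen-2-yl replacing 4-nitrophenyl

A few compounds are considered here, and "the series" means these few. Any claim that something is new, unique, unknown or untested is made for them only; others in the source may bear on it.

Measured compounds:
compound 1 `COc1cc(N2C(N)=C(C#N)C(c3ccc(OC)c4ccccc34)C3=C2CC(C)(C)CC3=O)cc(OC)c1OC`: 40%
compound 2 `COc1cc(N2C(N)=C(C#N)C(c3cccc([N+](=O)[O-])c3)C3=C2CC(C)(C)CC3=O)cc(OC)c1OC`: 30%
compound 3 `COc1cc(N2C(N)=C(C#N)C(c3ccc([N+](=O)[O-])cc3)C3=C2CC(C)(C)CC3=O)cc(OC)c1OC`: 70%

In a functional assay on Ehrlich cells (Mus musculus) for cytotoxicity, tested at 50 ug/mL (on this read-out lower numbers stand for a weaker effect and higher numbers for a stronger effect at the one concentration tested), compound 3 stands highest of the three numbers, with steps a number 30 percentage points higher from compound 1 to compound 3 (beyond the scatter) and a number 40 percentage points higher from compound 2 to compound 3 (beyond the scatter) both beyond the scatter, so it is the strongest of the measured set. Compound 1 and compound 2 are within the scatter of each other (a number 10 percentage points lower from compound 1 to compound 2 (within the scatter)).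

Compound 4 `COc1cc(N2C(N)=C(C#N)C(c3cccs3)C3=C2CC(C)(C)CC3=O)cc(OC)c1OC` is not yet measured. The change is thiophen-2-yl in place of 4-nitrophenyl on a saturated ring carbon. Among the measured compounds shown here, no measured step involves thiophen-2-yl; the bearing steps are those into compound 3, which show that the 4-nitrophenyl gives the strongest effect here. Replacing it is therefore expected to lower this assay. For compound 4 an expected step of a number 30 percentage points lower from compound 3 to compound 4 (beyond the scatter) follows. Compound 4 is estimated at 40%, between 20% and 65%.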

Compound 4, a percentage reported as activity, at one concentration (the size of the read-out at that concentration, not a potency): 15%
For compound 4 the middle estimate is 25 percentage points above the measured one; the whole stated range lies above it.
By their numbers in this assay, from the lowest: compound 4; then compounds 2 and 1 (each within the scatter of the next); then compound 3.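

In this assay thiophen-2-yl on this saturated ring carbon gives the weakest compound of the four, with a number 55 percentage points lower from compound 3 to compound 4 (beyond the scatter) and a number 15 percentage points lower from compound 2 to compound 4 (beyond the scatter) and also a number 25 percentage points lower from compound 1 to compound 4 (beyond the scatter). The earlier compounds shown here showed a spread between the two nitrophenyl isomers; compound 4 now shows that the read-out at this carbon can fall below that of all three larger groups. Nothing measured here accounts for the drop.

Still open, on these data alone, is whether a plain phenyl or a furan-2-yl at this carbon would read closer to compound 3 or to compound 4.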